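The source may report more compounds than this note shows. Statements on the series, on what has been measured and on what is new or still open speak of the compounds shown alone.

The study concerns a small set of analogues built around a shared core, all tested in a functional assay on BGC-823 cells (Homo sapiens) for antiproliferative activity, read by MTT assay, tested at 1 uM; on this read-out lower numbers stand for a weaker effect and higher numbers for a stronger effect at the one concentration tested. Compound 1 has the structure `COc1cc(C2=NN(C(C)=O)C(c3c(Cl)cccc3Cl)O2)cc(OC)c1OC`, and in this assay compound 1 gives -1.4%. Compound 2, with the structure `COc1cc(C2=NN(C(C)=O)C(c3cc(OC)c(OC)c(OC)c3)O2)cc(OC)c1OC`, gives in this assay -1.8%, and compound 3, with the structure `COc1cc(/C=N/NC(=O)c2cc(OC)c(OC)c(OC)c2)cc(OC)c1OC`, gives in this assay -5%. On these numbers compound 1 sits alongside compound 2 and compound 3: all three values lie within the scatter of one another, and none of them stands apart from the others.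

The account now turns from compound 1 to compound 4, whose structure is `COc1cc(C2=NN(C(C)=O)C(c3ccc(F)c(F)c3)O2)cc(OC)c1OC`. The change is counted as 3,4-difluorophenyl in place of 2,6-dichlorophenyl on a saturated ring carbon. No step between two measured compounds exists for this kind of change, so the expectation for compound 4 rests only on the three numbers shown, which all sit close to zero. It is therefore expected that the step of a number 1.4 percentage points higher from compound 1 to compound 4 (within the scatter) stays within the scatter. Compound 4 is estimated to give about 0%, within a range from -10% to 12%.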

Compound 4, a percentage reported as inhibition, at one concentration (the size of the read-out at that concentration, not a potency): 18.3%
Beside the measured number, compound 4's estimate is 18.3 percentage points below it; the measured number lies above the stated range.
By their numbers in this assay, from the lowest: compounds 3, 2 and 1 (each within the scatter of the next); then compound 4.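

For the compounds shown here, the change to 3,4-difluorophenyl from 2,6-dichlorophenyl on the saturated ring carbon gives a number 19.7 percentage points higher from compound 1 to compound 4 (beyond the scatter) in this assay, so this position can move the read-out beyond the scatter, which the earlier compounds, all within the scatter of one another, did not show. The two groups match in their counts of heavy atoms, hydrogen-bond donors and acceptors, so those counts do not separate them, and what differs is the halogen and the substitution pattern given in their names. No available evidence explains the rise.

The compounds shown leave open whether the gain follows the fluorine atoms or the substitution pattern of 3,4-difluorophenyl, a question that 3,4-dichlorophenyl or 2,6-difluorophenyl at the same carbon could address. Going by these compounds, how an aminophenyl group would read at this position also remains open.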